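Para-methyl in place of dichloro on the urea aryl

A few compounds are considered here, and "the series" means these few. Any claim that something is new, unique, unknown or untested is made for them only; others in the source may bear on it.

Among the three compounds measured in a functional assay on MDA-MB-231 cells (Homo sapiens) for cytotoxicity, read by MTT assay, with a stated time of 72 h (a higher number here means a weaker inhibitor, a lower number a stronger inhibitor), compound 3 `CN(C)CCNc1nc(-c2ccc(NC(=O)Nc3ccc(Cl)cc3Cl)cc2)nc2ccsc12` stands at the weak end: compound 3 gives 2450 nM, the highest number of the set. Compound 1 `CN(C)CCNc1nc(-c2ccc(NC(=O)Nc3ccc(F)cc3)cc2)nc2ccsc12` gives 540 nM and compound 2 `CN(C)CCNc1nc(-c2ccc(NC(=O)Nc3ccc(Cl)cc3)cc2)nc2ccsc12` gives 310 nM, so the two monohalogenated analogues sit close together (a 1.7-fold lower number from compound 1 to compound 2 (0.24 log units; within the scatter)), while both sit well clear of compound 3 (a 4.5-fold higher number from compound 1 to compound 3 (0.66 log units; beyond the scatter); a 7.9-fold higher number from compound 2 to compound 3 (0.90 log units; beyond the scatter)).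

The next compound, compound 4 `Cc1ccc(NC(=O)Nc2ccc(-c3nc(NCCN(C)C)c4sccc4n3)cc2)cc1`, carries 4-methylphenyl in place of 2,4-dichlorophenyl on an amide-type nitrogen. For the measured compounds named here, two measured steps bear on this change. The move from compound 2 to compound 3 added the second chloro, and the move from compound 1 to compound 3 swapped a single para substituent for the dichloro pattern; both cost potency by a modest but real margin. Going by the values given here, compound 4 returns to a single para substituent, now methyl, for which there is no direct precedent here, so the size of the methyl-versus-halogen difference is unknown, though compound 1 and compound 2 show that two different para groups gave numbers within the scatter of each other.

Compound 4 is therefore expected to give about 400 nM, with a plausible range from 150 nM to 1200 nM. That would correspond to an expected 6.1-fold lower number from compound 3 to compound 4 (0.79 log units; beyond the scatter).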

Compound 4, half-maximal inhibitory concentration: 2180 nM
Estimate against measurement, compound 4: 5.5-fold (0.74 log units) below; measured number above the stated range.
By their numbers in this assay, from the lowest: compounds 2 and 1 (each within the scatter of the next); then compounds 4 and 3 (each within the scatter of the next).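

Exchanging 2,4-dichlorophenyl for 4-methylphenyl on the amide-type nitrogen does not separate the two compounds in this assay (a 1.1-fold lower number from compound 3 to compound 4 (0.05 log units; within the scatter)), so removing both chloro groups and adding a methyl leaves the reading where the dichloro pattern had put it. Methyl in place of a single halogen gives a clear step in both available comparisons (a 7.0-fold higher number from compound 2 to compound 4 (0.85 log units; beyond the scatter); a 4.0-fold higher number from compound 1 to compound 4 (0.61 log units; beyond the scatter)), which shows that the lower numbers of compound 1 and compound 2 depend on what the group at this place is, and not merely on there being one group rather than two. Among these four compounds, a single halogen goes with the lower numbers, while compound 3 shows that halogen alone is not enough, and no measurement offered here explains why the methyl and dichloro compounds fall together.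

The compounds shown leave open whether an unsubstituted phenyl, a methoxy group or a trifluoromethyl group on this aryl ring would read with the monohalogenated pair or with compound 3 and compound 4. They also leave open whether the gap between halogen and methyl would persist if a morpholine replaced the dimethylamino group on the side chain.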